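The source may report more compounds than this note shows. Statements on the series, on what has been measured and on what is new or still open speak of the compounds shown alone.

Among the compounds with values here, in an ADME assay on Vero cells (Chlorocebus sabaeus) for cytotoxicity, with a stated time of 7 days (on this read-out lower numbers stand for higher toxicity in this test and higher numbers for lower toxicity in this test), the two compounds measured so far give no firm numbers. Compound 1, `COc1cccc(CN2C(=O)CN(C(=O)c3cc4cc(OC)ccc4[nH]3)C[C@@H]2COCc2ccccc2)c1`, reaches only a limit in this assay, > 10000 nM, not a measured value. Compound 2, `COc1ccc2[nH]c(C(=O)N3CC(=O)N(Cc4ccccc4)[C@@H](CN4CCC(C)CC4)C3)cc2c1`, likewise sits at a limit in this assay, > 30000 nM, so no number is known for it. Both values shown are limits, as the limit of > 10000 nM in this assay, at which 1 of the 2 values shown sits, and the limit of > 30000 nM in this assay, at which 1 of the 2 values shown sits, record, and compound 2 cannot be placed any more closely than that. Compound 3, `COc1ccc2[nH]c(C(=O)N3CC(=O)N(Cc4ccccc4)[C@@H](CN4CC5CC5C4)C3)cc2c1`, has not yet been measured in this assay. It differs from compound 2 by a group of 6 heavy atoms (5 carbon, 1 nitrogen; one three-membered non-aromatic ring of carbon only, one five-membered non-aromatic ring with 1 hetero atom) in place of a group of 7 heavy atoms (6 carbon, 1 nitrogen; one six-membered non-aromatic ring with 1 hetero atom), on a saturated chain carbon bound to a saturated ring carbon. Within the data shown here, no step between two measured compounds is available, so the effect of this change can only be expected. For compound 3 the change is estimated to be a number no higher from compound 2 to compound 3 (the limit leaves the size open), nothing beyond the scatter. Compound 3 is thus expected to give about 30000 nM in this assay, between 15000 nM and 60000 nM, most likely again only as a limit.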

Compound 3, half-maximal cytotoxic concentration: 13800 nM
For compound 3 the middle estimate is 2.2-fold (0.34 log units) above the measured one, outside the stated range (below it).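

With the 4-methylpiperidin-1-yl group replaced by a group holding a three-membered carbon ring and a five-membered ring with 1 hetero atom, on a saturated chain carbon bound to a saturated ring carbon, this assay shows an at least 2.1-fold lower number from compound 2 to compound 3 (0.33 log units; beyond the scatter). The earlier compounds shown here gave only limits. Compound 3 gives a firm 13800 nM, so a change at this place can move the read-out towards higher toxicity in this test. The full size of the step stays unknown because compound 2 has a limit and not a number: the limit of > 30000 nM in this assay, at which 1 of the 3 values shown sits.

The compounds shown leave open whether the shift goes with losing the methyl, with the smaller ring or with the three-membered ring. An unsubstituted piperidine and a plain pyrrolidine at this place would be needed to separate these.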